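Allyl for Bromo on Two Different Cores

The source may hold more compounds than are shown below. What is called first, only, known or untested is meant among the compounds shown, and "the series" means these compounds.

Measured compounds:
Compound 1, `C=CCOCc1cc(-c2cc(Br)ccc2OC)no1`: 90400 nM
Compound 2, `C=CCOCc1cc(-c2cc(CC=C)ccc2OC)no1`: 28700 nM
Compound 3, `C=CCn1ccc(-c2cc(Br)ccc2OC)n1`: a limit, > 200000 nM

In a functional assay on BV-2 cells (Mus musculus) for inhibition, read by Griess assay, with a stated time of 24 h (a higher number here means a weaker inhibitor, a lower number a stronger inhibitor), compound 1 gives 90400 nM. Compound 2 differs from it in one place:
allyl in place of bromo on an aromatic carbon
That change gave the step of a 3.1-fold lower number from compound 1 to compound 2 (0.50 log units; beyond the scatter).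

Compound 3 is reported in this assay only as a limit, > 200000 nM. The difference between the core of compound 1 and the core of compound 3 is not broken down here. Compound 4, `C=CCc1ccc(OC)c(-c2ccn(CC=C)n2)c1`, is not yet measured; it differs from compound 3 in one place:
allyl in place of bromo on an aromatic carbon
Within the data shown here, this is the same kind of change as the one from compound 1 to compound 2, though not the same: in compound 1 the changed carbon is meta to a large group, in compound 3 it is meta to a group of 8 heavy atoms.

From compound 3 to compound 4 a step of about an at least 1.6-fold lower number from compound 3 to compound 4 (0.22 log units; that floor lies within the scatter) is expected in this assay, resting on the step of a 3.1-fold lower number from compound 1 to compound 2 (0.50 log units; beyond the scatter) seen on the other core. Because compound 3 sits at the limit (the limit of > 200000 nM in this assay, at which 1 of the 3 values shown sits), it is possible that compound 4 is again reported only as a limit. The number expected for compound 4 is 120000 nM, estimated to lie between 40000 nM and 300000 nM.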

Compound 4, half-maximal inhibitory concentration: > 200000 nM
Compound 4: no number, only a limit (the forecaster's own chance of this, stated with the estimate: 50%); middle value at least 1.6-fold (0.22 log units) from the limit.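

In this assay compound 4 gives > 200000 nM, a limit of the assay and not a number. Compound 3 is also reported only as a limit, so no step can be read between compound 3 and compound 4: the limit of > 200000 nM in this assay, at which 2 of the 4 values shown sit. The compounds shown leave open whether allyl in place of bromo on this core has any effect comparable to a 3.1-fold lower number from compound 1 to compound 2 (0.50 log units; beyond the scatter) on the other core.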